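The source may report more compounds than this note shows. Statements on the series, on what has been measured and on what is new or still open speak of the compounds shown alone.

Series notes. In a functional assay on OVCAR-4 cells (Homo sapiens) for cytotoxicity, read by sulforhodamine B assay, with a stated time of 48 h, tested at 10 uM (on this read-out higher numbers stand for a weaker effect at the one concentration tested and lower numbers for a stronger effect), compound 1 `COc1cc(-c2cc(/C=C/C(=O)c3ccc(Cl)c(Cl)c3)[nH]n2)cc(OC)c1OC` gives 52%, compound 2 `COc1ccc(C(=O)/C=C/c2cc(-c3cc(OC)c(OC)c(OC)c3)n[nH]2)cc1OC` gives 23% and compound 3 `COc1cc(-c2cc(/C=C/C(=O)c3ccc(F)c(F)c3)[nH]n2)cc(OC)c1OC` gives 17%. Compound 2 thus stands second highest of the three numbers, close to compound 3 and well apart from compound 1. Every measured step swaps the aryl group on the carbonyl carbon: a number 29 percentage points lower from compound 1 to compound 2 (beyond the scatter), a number 35 percentage points lower from compound 1 to compound 3 (beyond the scatter), and a number 6 percentage points lower from compound 2 to compound 3 (within the scatter). Compound 4 `COc1cc(C(=O)/C=C/c2cc(-c3cc(OC)c(OC)c(OC)c3)n[nH]2)cc(OC)c1OC` differs from compound 2 by methoxy in place of hydrogen on an aromatic carbon. Within the data shown here, no measured step adds a single methoxy on an aromatic carbon, so there is no direct precedent. The aryl swaps show that this part of the molecule can move the number, yet the swap nearest in kind stayed within the scatter. A small step is therefore expected in this assay, if any, in either direction. Compound 4 is expected at 25%, with a range of 8% to 45%. The expected step is a number 2 percentage points higher from compound 2 to compound 4 (within the scatter).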

Compound 4, a percentage reported as activity, at one concentration (the size of the read-out at that concentration, not a potency): -100%
For compound 4 the middle estimate is 125 percentage points above the measured one; the whole stated range lies above it.
By their numbers in this assay, from the lowest: compound 4; then compounds 3 and 2 (each within the scatter of the next); then compound 1.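

In this assay, methoxy in place of hydrogen on an aromatic carbon, ortho to a methoxy group and meta to a large group, gives a number 123 percentage points lower from compound 2 to compound 4 (beyond the scatter). This position is therefore far more sensitive than the earlier aryl swaps suggested: one small added group moves the number more than any of those exchanges. No measurement offered here accounts for the step.

Going by these compounds, whether the step is specific to methoxy remains open. A hydroxy group, an amine or a longer ether chain on the same aromatic carbon would test this.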